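From a carboxylic acid to an aminoethyl amide

This account rests on a few compounds, and the source may have more. Where it says the series, first, only, none or still open, it means among the compounds named here.

In an ADME assay on HEK293 cells (Homo sapiens) for cytotoxicity, read by CCK-8 assay, with a stated time of 48 h (a lower number here means a stronger inhibitor, a higher number a weaker inhibitor), compound 3 (`COc1ccc(/C=C\c2cc(OC)c(OC)c(OC)c2)cc1OCc1ccc(CN2CC[C@H](C(=O)O)C2)cc1`) gives > 50000 nM, which is a limit and not a number. Compound 3 thus stands at the limit of > 50000 nM in this assay, at which 2 of the 3 values shown sit. Compound 1 (`COc1ccc(/C=C\c2cc(OC)c(OC)c(OC)c2)cc1OCc1ccc(CN2CCCCC2C(=O)O)cc1`) gives > 50000 nM, also a limit. Compound 2 (`COc1ccc(/C=C\c2cc(OC)c(OC)c(OC)c2)cc1OCc1ccc(CN2CCCCC2C(=O)NCCNC(=O)OC(C)(C)C)cc1`) gives 48000 nM, a measured number. Compound 4 (`COc1ccc(/C=C\c2cc(OC)c(OC)c(OC)c2)cc1OCc1ccc(CN2CCCCC2C(=O)NCCN)cc1`) differs through (2-((2-aminoethyl)carbamoyl)piperidin-1-yl in place of 3-carboxypyrrolidin-1-yl on a saturated chain carbon bound to an aromatic carbon). Going by the values given here, two measured steps bear on this change: an at least 1.0-fold lower number from compound 1 to compound 2 (0.01 log units; that floor lies within the scatter), and a step that the two limits leave unreadable from compound 1 to compound 3. Neither shows a step beyond the scatter, so no large step is expected in this assay, though any movement would be expected towards a lower number. The step expected is an at least 1.2-fold lower number from compound 3 to compound 4 (0.09 log units; that floor lies within the scatter). Compound 4 is estimated at 40000 nM, within an expected range of 15000 nM to 60000 nM.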

Compound 4, half-maximal inhibitory concentration: > 50000 nM
Compound 4 ended at the assay's limit (the forecaster's own chance of this, stated with the estimate: 45%); at least 1.2-fold (0.09 log units) between middle value and limit.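

In this assay compound 4, with its free (2-aminoethyl)amino amide, ends at a limit, as the two carboxylic acids compound 1 and compound 3 do: (the limit of > 50000 nM in this assay, at which 3 of the 4 values shown sit). Hydrogen in place of tert-butoxycarbonyl on the amine nitrogen gives an at least 1.0-fold higher number from compound 2 to compound 4 (0.01 log units; that floor lies within the scatter), so the capped and the free amine are not told apart in this assay. The steps to compound 4 from compound 1 and from compound 3 cannot be read, since both ends are limits.

On these data alone, whether a longer chain or a dimethylamino group at the chain end would bring a measurable number remains open.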